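A few compounds are considered here, and "the series" means these few. Any claim that something is new, unique, unknown or untested is made for them only; others in the source may bear on it.

Compound 1 `O=C(Nn1c(-c2cccc([N+](=O)[O-])c2)nc2c(-c3ccc(Cl)cc3)n[nH]c2c1=O)c1cccnc1` is the starting point of this small set. In a functional assay on A549 cells (Homo sapiens) for cytotoxicity, read by sulforhodamine B assay, with a stated time of 2 days, tested at 100 uM (on this read-out lower numbers stand for less inhibition and higher numbers for more inhibition at the one concentration tested (going by the name of the read-out)), compound 1 gives 19.7%, the highest of the three numbers recorded. Compound 3 `O=C(Nn1c(-c2cccc([N+](=O)[O-])c2)nc2c(-c3cccs3)n[nH]c2c1=O)c1cccnc1` gives 10.2% and compound 2 `O=C(Nn1c(-c2cccc([N+](=O)[O-])c2)nc2c(-c3ccco3)n[nH]c2c1=O)c1cccnc1` gives 1.51%; the step of a number 9.5 percentage points lower from compound 1 to compound 3 (within the scatter) stays within the scatter, whereas a number 18.2 percentage points lower from compound 1 to compound 2 (beyond the scatter) is a modest drop beyond it. Compound 4 `O=C(Nn1c(-c2cccc([N+](=O)[O-])c2)nc2c(-c3ccc(Cl)cc3)n[nH]c2c1=O)c1ccccc1` is the unmeasured partner of compound 1. The difference between them is set out here: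
phenyl in place of pyridin-3-yl on a carbonyl carbon
Thus benzamido stands where ((pyridin-3-yl)carbonyl)amino stood, and the rest of the shared core is unchanged. Going by the values given here, none of the measured steps touch this carbonyl carbon; each exchanges the group on the aromatic carbon instead, so no step bears directly on the change. For that reason a step within the scatter is expected for a number 0.3 percentage points higher from compound 1 to compound 4 (within the scatter). Compound 4 is therefore estimated at 20%, with a range from 5% to 38%.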

Compound 4, a percentage reported as inhibition, at one concentration (the size of the read-out at that concentration, not a potency): 88.6%
Compound 4: middle estimate off by 68.6 percentage points, on the low side; measured number above the stated range.
By their numbers in this assay, from the lowest: compounds 2, 3 and 1 (each within the scatter of the next, the first and the last beyond it); then compound 4.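

The carbonyl carbon proves far more sensitive than the aromatic carbon varied earlier: in this assay, phenyl in place of pyridin-3-yl gives a number 68.9 percentage points higher from compound 1 to compound 4 (beyond the scatter), a larger step than any among the first three compounds. The exchange replaces a single ring nitrogen with carbon and leaves the heavy-atom count unchanged. Nothing available here accounts for the size of this step. As far as these compounds go, whether the exchange gives a similar step with furan-2-yl or thiophen-2-yl on the aromatic carbon remains open, as does the effect of cyclohexyl or methyl on the carbonyl carbon.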